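The source may hold more compounds than are shown below. What is called first, only, known or untested is meant among the compounds shown, and "the series" means these compounds.

Measured in an ADME assay on Huh-7 cells (Homo sapiens) for cytotoxicity, with a stated time of 72 h; on this read-out higher numbers stand for lower toxicity in this test and lower numbers for higher toxicity in this test:
- compound 1 `C/C(=C\c1nn(CCC(C)C)c(=O)c(C2=NS(=O)(=O)c3cc(NS(C)(=O)=O)ccc3N2)c1O)C(F)(F)F`: > 33000 nM
- compound 2 `CC(C)CCn1nc(CCC(F)(F)F)c(O)c(C2=NS(=O)(=O)c3cc(NS(C)(=O)=O)ccc3N2)c1=O`: > 33000 nM
- compound 3 `CCCC(C)n1nc(-c2cccs2)c(O)c(C2=NS(=O)(=O)c3cc(NS(C)(=O)=O)ccc3N2)c1=O`: > 33000 nM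

Each of these entries is a limit and not a number. Compound 3 therefore has no exact place in the series: the limit of > 33000 nM in this assay, at which 3 of the 3 values shown sit.

Compound 4 `CS(=O)(=O)Nc1ccc2c(c1)S(=O)(=O)N=C(c1c(O)c(-c3cccs3)nn(CC3(C(F)(F)F)CCC3)c1=O)N2` carries (1-(trifluoromethyl)cyclobutyl)methyl in place of 1-methylbutyl on an aromatic nitrogen, and the thiophen-2-yl group stays as in compound 3: (1-(trifluoromethyl)cyclobutyl)methyl in place of 1-methylbutyl on an aromatic nitrogen.

Within the data shown here, the only measured step is a step that the two limits leave unreadable from compound 1 to compound 2. It concerns an aromatic carbon rather than this nitrogen, and it gives no size to carry over. The expectation therefore rests mainly on compound 3, whose > 33000 nM is again only a limit. No shift beyond the scatter is expected in this assay, in either direction, and the estimated change is a step that the limit leaves unreadable from compound 3 to compound 4. Compound 4 is most likely to be reported as a limit too. For compound 4 the expected value is 35000 nM, with an estimated range from 12000 nM to 60000 nM.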

Compound 4, half-maximal cytotoxic concentration: > 1000 nM
Compound 4 ended at the assay's limit; the forecaster's own chance of this, stated with the estimate: 75%; the middle value is on the limit's open side.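

The step from compound 3 to compound 4 cannot be read in this assay: both entries are limits and not numbers. The compounds shown leave open the exact values of compound 3 and compound 4, and so whether (1-(trifluoromethyl)cyclobutyl)methyl in place of 1-methylbutyl on an aromatic nitrogen shifts this read-out at all.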